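Removing a second chloro from the shared core

The compounds below may be only part of what the source reports. "The series", "measured", "known", "first", "only" and "open" are said of these compounds alone.

Compound 1 `ClCc1ccc(Cn2cnc3c(Cl)ncnc32)cc1`: 57500 nM
Compound 2 `ClCc1ccccc1Cn1cnc2c(Cl)nc(Cl)nc21`: 9550 nM

In a functional assay on A498 cells (Homo sapiens) for cytotoxicity, read by sulforhodamine B assay, with a stated time of 48 h (a lower number here means that less compound is tolerated, a higher number that more compound is tolerated), compound 2 gives the lower of the two numbers; the nearest is compound 1 with 57500 nM, beyond the scatter. Within the data shown here, the two compounds differ in more than one place, so no single step is separated. Compound 3 `ClCc1ccccc1Cn1cnc2c(Cl)ncnc21` is compound 2 with hydrogen in place of chloro on an aromatic carbon, on an aromatic carbon between two ring nitrogen atoms of the core. Among the measured compounds shown here, no measured pair isolates this change. Compound 3 is expected to show a 2.1-fold higher number from compound 2 to compound 3 (0.32 log units; beyond the scatter), a moderate upward step. The estimate for compound 3 is 20000 nM, with a range from 6000 nM to 70000 nM.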

Compound 3, concentration lethal to 50% of the cells: 58900 nM
Estimate against measurement, compound 3: 2.9-fold (0.47 log units) below; the range from low to high includes it.
By their numbers in this assay, from the lowest: compound 2; then compounds 1 and 3 (each within the scatter of the next).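

Among these compounds, this is the first single change that can be read on its own: in this assay, hydrogen in place of chloro on an aromatic carbon, between two ring nitrogen atoms of the core, gives a 6.2-fold higher number from compound 2 to compound 3 (0.79 log units; beyond the scatter). The chloro at this position therefore makes a difference beyond the scatter to the number read. Nothing available accounts for the size of this step.

From the compounds shown here alone, whether this position responds only to chloro or in a similar way to fluoro, a methoxy group or an amine remains open.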